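The compounds below may be only part of what the source reports. "The series", "measured", "known", "first", "only" and "open" are said of these compounds alone.

Measured compounds:
Compound 1, `COc1ccc(/C=C/C(=O)NCCCC(C)Nc2cc(OC)cc3cccnc23)cc1`: in an ADME assay on L6 cells (Rattus norvegicus) for cytotoxicity, read by resazurin assay, with a stated time of 70 h (on this read-out lower numbers stand for stronger inhibition and higher numbers for weaker inhibition), compound 1 gives > 240000 nM, which is a limit of the assay and not a number.
Compound 2, `COc1cc(NC(C)CCCNC(=O)/C=C/c2ccc(OC)c(OC)c2)c2ncccc2c1`: in this assay compound 2 gives > 220000 nM, again a limit and not a number.
Compound 3, `COc1cc(NC(C)CCCNC(=O)/C=C/c2cccc(C(F)(F)F)c2)c2ncccc2c1`: in this assay compound 3 gives 16200 nM.

Among the compounds with values here, compound 3 thus stands as the only measured number in this assay; the two other values are limits. The step that the two limits leave unreadable from compound 1 to compound 2 cannot be read, since compound 1 sits at the limit of > 240000 nM in this assay, at which 1 of the 3 values shown sits, and compound 2 at the limit of > 220000 nM in this assay, at which 1 of the 3 values shown sits. The two steps that run to compound 3, an at least 14-fold lower number from compound 1 to compound 3 (1.17 log units; beyond the scatter) and an at least 13-fold lower number from compound 2 to compound 3 (1.13 log units; beyond the scatter), are both large and both replace a methoxy-bearing phenyl by a trifluoromethyl-bearing phenyl.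

Compound 4, `COc1cc(NC(C)CCCNC(=O)/C=C/c2cc(C(F)(F)F)cc(C(F)(F)F)c2)c2ncccc2c1`, differs from compound 3 by trifluoromethyl in place of hydrogen on an aromatic carbon. Within the data shown here, no measured step adds a second trifluoromethyl to a ring that already carries one, so the two large steps to compound 3 bear on it only loosely: they mark the direction in which a trifluoromethyl group has moved the number, not what a second one does. A smaller move in the same direction, within or just beyond the scatter, is the working expectation. Compound 4 is therefore expected at 9000 nM, with a range from 3000 nM to 30000 nM. The expected step is a 1.8-fold lower number from compound 3 to compound 4 (0.26 log units; within the scatter).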

Compound 4, half-maximal inhibitory concentration: 158000 nM
For compound 4 the middle estimate is 18-fold (1.24 log units) below the measured one; the measured number lies above the stated range.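

Adding a second trifluoromethyl, on an aromatic carbon meta to a large group and meta to a trifluoromethyl group, gives a 9.8-fold higher number from compound 3 to compound 4 (0.99 log units; beyond the scatter) in this assay, so the number moves against the direction of the earlier steps to compound 3. Those steps, an at least 14-fold lower number from compound 1 to compound 3 (1.17 log units; beyond the scatter) and an at least 13-fold lower number from compound 2 to compound 3 (1.13 log units; beyond the scatter), therefore do not extend to a further trifluoromethyl on the same ring: in this short series, one trifluoromethyl group accompanies a lower number, while a second on that ring accompanies a higher one, which on this read-out stands for weaker inhibition. The values shown contain no measured property that bears on this reversal.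

Open, from the compounds shown here alone, is whether a chlorine atom or a nitrile in place of the second trifluoromethyl would move the number in the same direction as that group or stay closer to compound 3. Also open, going by these compounds, is whether the same step would appear with a longer chain in place of the chain of compound 3, or with an amine on the ring in place of the second trifluoromethyl.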